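Amine substitution on the shared core: cytotoxicity notes

The source may hold more compounds than are shown below. What is called first, only, known or untested is meant among the compounds shown, and "the series" means these compounds.

compound 1 `N#Cc1c(N)[n+]([O-])c2ccc(Cl)cc2[n+]1[O-]` — a limit only, > 100 ug/mL
compound 2 `CNc1c(C#N)[n+]([O-])c2cc(Cl)ccc2[n+]1[O-]` — a limit only, > 100 ug/mL

In a functional assay on Ehrlich cells (Mus musculus) for cytotoxicity, read by trypan blue exclusion (a higher number here means a weaker inhibitor, a lower number a stronger inhibitor), compound 1 gives only a limit, > 100 ug/mL. In this assay compound 2 also gives only a limit, > 100 ug/mL. The step that the two limits leave unreadable from compound 1 to compound 2 is unreadable, since both values sit at the limit of > 100 ug/mL in this assay, at which 2 of the 2 values shown sit; compound 2 therefore stands at that limit and nowhere more exact.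

Compound 3 `CC(=O)N(C(C)=O)c1c(C#N)[n+]([O-])c2cc(Cl)ccc2[n+]1[O-]` differs from compound 2 by diacetylamino in place of methylamino on an aromatic carbon. Among the compounds with values here, no measured step is readable enough to bear on this change. Compound 3 is expected at 150 ug/mL, within 40 ug/mL to 600 ug/mL. The expected step that the limit leaves unreadable from compound 2 to compound 3 is none beyond the scatter, most likely again a limit.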

Compound 3, half-maximal inhibitory concentration: > 100 ug/mL
Compound 3 ended at the assay's limit; the forecaster's own chance of this, stated with the estimate: 70%; the middle value lies beyond the limit too.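

In this assay, within the data shown here, compound 1, compound 2 and compound 3 all give only a limit, so no step among them can be read. The compounds shown leave open which change on the shared core, if any, would bring a value within the measurable range.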